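The source may report more compounds than this note shows. Statements on the series, on what has been measured and on what is new or still open speak of the compounds shown alone.

For the measured compounds named here, compound 3 `COc1ccc(Sc2nc3cc(N)cc(N)c3nc2-c2ccccc2)cc1` is the only member of this set with a measured number in a functional assay on NCI-H522 cells (Homo sapiens) for inhibition, read by sulforhodamine B assay, with a stated time of 48 h (on this read-out lower numbers stand for stronger inhibition of growth and higher numbers for weaker inhibition of growth), where compound 3 gives 3240 nM. The two other results are limits rather than numbers. Compound 1 `COc1cc(CNc2nc3cc(N)cc(N)c3nc2-c2ccccc2)cc(OC)c1OC` gives only a limit, < 50200 nM. Compound 2 `Nc1cc(N)c2nc(-c3ccccc3)c(NCc3ccc(F)cc3)nc2c1` likewise gives only a limit, < 100000 nM. Going by the values given here, the single step between measured compounds, a step that the limit leaves unreadable from compound 2 to compound 3, is therefore unreadable, and no measured step bears on the change leading to compound 4 `Nc1cc(N)c2nc(-c3ccccc3)c(Sc3ccc(F)cc3)nc2c1`, which is fluoro in place of methoxy on an aromatic carbon, para to a large group. Among the compounds with values here, with no comparable step available, a step within the usual scatter is expected, a 1.2-fold higher number from compound 3 to compound 4 (0.09 log units; within the scatter). Compound 4 is accordingly estimated at 4000 nM in this assay, ranging from 1300 nM to 13000 nM.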

Compound 4, concentration for 50% growth inhibition: < 100000 nM
Compound 4 was reported as a limit; the forecaster's own chance of this, stated with the estimate: 10%; the middle value lies beyond the limit too.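

Compound 4 gives only a limit, < 100000 nM, so its steps from compound 2 and compound 3 cannot be read. As far as these compounds go, whether (4-fluorophenyl)sulfanyl and (4-methoxyphenyl)sulfanyl differ in this assay remains open, as does how either compares with (4-fluorobenzyl)amino.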